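This account rests on a few compounds, and the source may have more. Where it says the series, first, only, none or still open, it means among the compounds named here.

Measured compounds:
compound 1, `COc1ccc(-c2ccc(COCCCCCN3C[C@H](O)[C@@H](O)[C@H](O)[C@H]3CO)cc2)cc1`: 25 nM
compound 2, `COc1cccc(-c2ccc(COCCCCCN3C[C@H](O)[C@@H](O)[C@H](O)[C@H]3CO)cc2)c1`: 150 nM
compound 3, `N#Cc1ccc(-c2ccc(COCCCCCN3C[C@H](O)[C@@H](O)[C@H](O)[C@H]3CO)cc2)cc1`: 150 nM

All three share the same core and are compared in an assay on isolated protein for inhibition of ceramide glucosyltransferase (Homo sapiens); a lower number here means a stronger inhibitor, a higher number a weaker inhibitor. Compound 3 stands level with compound 2, and the two together give the highest numbers of the three; the nearest is compound 2, with no change at the digits printed from compound 2 to compound 3 (within the scatter), and the furthest is compound 1, with a 6.0-fold higher number from compound 1 to compound 3 (0.78 log units; beyond the scatter). The two measured steps away from compound 1 are alike in size: a 6.0-fold higher number from compound 1 to compound 2 (0.78 log units; beyond the scatter) and a 6.0-fold higher number from compound 1 to compound 3 (0.78 log units; beyond the scatter).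

The next compound is compound 4, `OC[C@@H]1[C@@H](O)[C@H](O)[C@@H](O)CN1CCCCCOCc1ccc(-c2ccc(F)nc2)cc1`. The change from compound 3 is 6-fluoropyridin-3-yl in place of 4-cyanophenyl on an aromatic carbon. Within the data shown here, no measured step exchanges an aryl ring for a heteroaryl ring, so none of the three steps bears on this change directly; they show only that a replacement on this ring moves this assay by a modest amount, in either direction from compound 1. The change here swaps one hydrogen-bond acceptor for another and removes the triple bond outside aromatic rings. Given the spread seen, compound 4 is expected to land near compound 3, with the step of a 1.5-fold lower number from compound 3 to compound 4 (0.18 log units; within the scatter) judged small. The estimated value for compound 4 is 100 nM, in a range of 30 nM to 400 nM.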

Compound 4, half-maximal inhibitory concentration: 750 nM
Compound 4: middle estimate off by 7.5-fold (0.88 log units), on the low side, outside the stated range (above it).
By their numbers in this assay, from the lowest: compound 1; then compounds 2 and 3 (each within the scatter of the next); then compound 4.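

In this assay, 6-fluoropyridin-3-yl sits above the level that the 3-methoxyphenyl and 4-cyanophenyl groups share, in two steps of equal size (a 5.0-fold higher number from compound 3 to compound 4 (0.70 log units; beyond the scatter); a 5.0-fold higher number from compound 2 to compound 4 (0.70 log units; beyond the scatter)), so the earlier plateau at this position is not a ceiling. Set against 4-methoxyphenyl, the same group gives the only step in the set printed as large (a 30-fold higher number from compound 1 to compound 4 (1.48 log units; beyond the scatter)), which widens the range this position can span well beyond what the earlier replacements showed, and compound 4 now has the highest number of the four. Nothing available accounts for the size of this step.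

The change brings in a ring nitrogen and a fluorine together, and the compounds shown do not separate them: a 4-fluorophenyl or an unsubstituted pyridin-3-yl group would tell the two apart. Also open, going by these compounds, is whether the lowest number, held by the 4-methoxyphenyl group, carries over to a 6-methoxypyridin-3-yl or a 4-ethoxyphenyl group, which would show whether the ring nitrogen can be tolerated with an alkoxy group in place of the fluorine.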